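The source may hold more compounds than are shown below. What is called first, only, known or untested is meant among the compounds shown, and "the series" means these compounds.

In an in vitro ADME assay on microsomes from liver (Homo sapiens) for metabolic stability, tested at 1 uM (on this read-out higher numbers stand for a longer-lived compound and lower numbers for a shorter-lived compound), compound 1 (`CC(C)[C@]1(C(=O)N2C[C@@H]3C[C@H]2CN3C(=O)CC(C)(C)C)CC[C@@H](NC2CCOCC2)C1`) gives > 2 h, which is a limit of the assay and not a number. Compound 2 (`CC(C)[C@]1(C(=O)N2C[C@@H]3C[C@H]2CN3C(=O)C2CC2)CC[C@@H](NC2CCOCC2)C1`) gives > 2 h, again a limit. Going by these compounds, compound 3 (`CO[C@@H]1COCC[C@@H]1N[C@@H]1CC[C@@](C(=O)N2C[C@@H]3C[C@H]2CN3C(=O)CC(C)(C)C)(C(C)C)C1`) gives > 2 h, also a limit, so its true half-life is unknown. The evidence so far is therefore (the limit of > 2 h in this assay, at which 3 of the 3 values shown sit).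

Compound 4 (`CO[C@@H]1COCC[C@@H]1N[C@@H]1CC[C@@](C(=O)N2C[C@@H]3C[C@H]2CN3C(=O)C2CCCC2)(C(C)C)C1`) has not yet been measured. It differs from compound 3 by cyclopentyl in place of neopentyl on a carbonyl carbon, with cyclopentyl in place of neopentyl on a carbonyl carbon. The closest measured change is a step that the two limits leave unreadable from compound 1 to compound 2, which also replaces neopentyl on a carbonyl carbon. The other is a step that the two limits leave unreadable from compound 1 to compound 3, where methoxy replaces hydrogen on a saturated ring carbon. Neither has a readable size, so neither supports a direction, and no change beyond the usual scatter is expected. The expected change is a step that the limit leaves unreadable from compound 3 to compound 4. A further report as a limit is the likeliest outcome. For compound 4 the estimate is 3 h, with an expected range of 1.3 h to 7 h.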

Compound 4, half-life: > 2 h
Compound 4: only a limit was reported; the forecaster's own chance of this, stated with the estimate: 75%; the middle value lies beyond the limit too.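

Compound 3 and compound 4 are both reported only as limits in this assay, so no size can be read for the step between them or for any other step here: the limit of > 2 h in this assay, at which 4 of the 4 values shown sit.

How long any of these compounds truly lasts, and whether cyclopentyl in place of neopentyl changes the half-life at all, stays open.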